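This account rests on a few compounds, and the source may have more. Where it says the series, first, only, none or still open, it means among the compounds named here.

Compound 1, `CCSCCC12CCC(c3nnc(-c4ccccc4C(F)(F)F)n3C)(CC1)CC2`: in a functional assay on the whole organism (strain ICR) for inhibition, with Mus musculus as the target, with a stated time of 4 h, at a dose of 10 mg/kg by the oral route (a lower number here means less inhibition, a higher number more inhibition at the dose given (going by the name of the read-out)), compound 1 gives 79%.
Compound 2, `Cn1c(-c2ccccc2C(F)(F)F)nnc1C12CCC(CCCC(C)(F)F)(CC1)CC2`: compound 2 gives 99%.
Compound 3, `CCS(=O)(=O)CCCCC12CCC(c3nnc(-c4ccccc4C(F)(F)F)n3C)(CC1)CC2`: compound 3 gives 90%.

Compound 3 stands second highest of the three numbers; the step of a number 9 percentage points lower from compound 2 to compound 3 (within the scatter) lies within the scatter, while the step of a number 11 percentage points higher from compound 1 to compound 3 (beyond the scatter) lies beyond it. Compound 4, `CCOCC12CCC(c3nnc(-c4ccccc4C(F)(F)F)n3C)(CC1)CC2`, differs from compound 3 by ethoxy in place of 3-(ethylsulfonyl)propyl on a saturated chain carbon bound to a saturated ring carbon. The measured steps that bear on this change, a number 11 percentage points higher from compound 1 to compound 3 (beyond the scatter) and a number 20 percentage points higher from compound 1 to compound 2 (beyond the scatter), were modest and show that altering the chain at this position has moved the read-out only modestly, with the highest numbers for the longer chains. Going by the values given here, the much shorter ethoxy chain has no direct precedent, so a modest fall in this assay is expected, or none beyond the scatter. For compound 4 the expected step is a number 10 percentage points lower from compound 3 to compound 4 (within the scatter), giving an estimate of 80%, within the range 55% to 98%.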

Compound 4, a percentage reported as inhibition, in the whole organism at one dose (the size of the read-out at that dose, not a potency): 44%
Estimate against measurement, compound 4: 36 percentage points above; measured number outside the range, below it.
By their numbers in this assay, from the lowest: compound 4; then compound 1; then compounds 3 and 2 (each within the scatter of the next).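

In this assay ethoxy on the saturated chain carbon bound to a saturated ring carbon gave a number 46 percentage points lower from compound 3 to compound 4 (beyond the scatter) and a number 55 percentage points lower from compound 2 to compound 4 (beyond the scatter) and a number 35 percentage points lower from compound 1 to compound 4 (beyond the scatter) as well. The earlier changes to this chain had moved the read-out only modestly, so this position proves sensitive to the group it carries, and ethoxy stands lowest of the four. Nothing available accounts for the fall. The compounds shown leave open whether it follows the shorter chain or its oxygen. A longer ether such as butoxy, or an amine, would bear on that question.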